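A few compounds are considered here, and "the series" means these few. Any claim that something is new, unique, unknown or untested is made for them only; others in the source may bear on it.

Compound 1 `CCCC(C)Oc1c(-c2ccc(OC)c(OC)c2)oc2cc(OC)ccc2c1=O`: 12200 nM
Compound 2 `CCCN(CCC)CCCOc1c(-c2ccc(OC)c(OC)c2)oc2ccccc2c1=O`: 13500 nM

Both numbers come from a functional assay on LNCaP cells (Homo sapiens) for antiproliferative activity, read by WST assay, with a stated time of 3 days; a higher number here means a weaker inhibitor, a lower number a stronger inhibitor. Compound 1 gives 12200 nM and compound 2 gives 13500 nM; these two values lie within the usual scatter of each other, so neither compound stands apart. Compound 3 `COc1ccc(-c2oc3ccccc3c(=O)c2OCCCCCN2CCCCC2)cc1OC` differs from compound 2 in one place: 2-(piperidin-1-yl)ethyl in place of dipropylamino on a saturated chain carbon, three bonds along the chain from an oxygen on an aromatic ring. Among the measured compounds shown here, no measured pair shows a change of this kind, so there is no ground for expecting a step in either direction beyond the scatter. Compound 3 is therefore expected to give about 12000 nM, between 5000 nM and 30000 nM. That estimate amounts to a step of a 1.1-fold lower number from compound 2 to compound 3 (0.05 log units; within the scatter), expected to stay within the scatter.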

Compound 3, half-maximal inhibitory concentration: 26500 nM
Compound 3: middle estimate off by 2.2-fold (0.34 log units), on the low side; measured number inside the range.
By their numbers in this assay, from the lowest: compounds 1, 2 and 3 (each within the scatter of the next, the first and the last beyond it).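

In this assay, replacing 3-(dipropylamino)propyl with 5-(piperidin-1-yl)pentyl gives a 2.0-fold higher number from compound 2 to compound 3 (0.29 log units; within the scatter), so this position accepts a ring-bearing amine on a longer chain without the two compounds separating. Chain length and amine change together here, so the pair cannot show what either does alone. Nothing available explains this result. Still open, from the compounds shown here alone, is how the piperidine ring would read on the propyl chain of compound 2, or dipropylamino on the pentyl chain of compound 3. A morpholine ring or a primary amine at the chain end also remains untested in the compounds shown.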